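The source may report more compounds than this note shows. Statements on the series, on what has been measured and on what is new or still open speak of the compounds shown alone.

Compound 1 `O=C(CC1c2ccccc2N=C(N2CCCCC2)N1c1ccccc1)NCc1ccc(NS(=O)(=O)c2ccc(F)cc2)cc1`: 110 nM
Compound 2 `NCCCCCNC1=Nc2ccccc2C(CC(=O)NCc2ccccc2)N1c1ccc(-c2ccccc2)cc1`: 130 nM
Compound 3 `CC(C)(C)OC(=O)NCCCCCNC1=Nc2ccccc2C(CC(=O)NCc2ccccc2)N1c1ccc(-c2ccccc2)cc1`: 160 nM

In an assay on HEK293 cells for inhibition of Voltage-dependent T-type calcium channel subunit alpha-1G (Homo sapiens) (a higher number here means a weaker inhibitor, a lower number a stronger inhibitor), compound 1 carries the lowest of the three numbers, though its gaps to compound 2 and to compound 3 both fall within the scatter. Among the compounds with values here, the single measured step, a 1.2-fold higher number from compound 2 to compound 3 (0.09 log units; within the scatter), concerns a remote amine and is itself within the scatter.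

Compound 4 `Cc1ccc(S(=O)(=O)Nc2ccc(CNC(=O)CC3c4ccccc4N=C(N4CCCCC4)N3c3ccccc3)cc2)cc1` differs from compound 1 by methyl in place of fluoro on an aromatic carbon. Within the data shown here, no measured step touches this part of the molecule, and the one step that exists shows no movement beyond the scatter, so nothing in these data points to a shift in either direction. The step is therefore expected to be a 1.1-fold higher number from compound 1 to compound 4 (0.04 log units; within the scatter). Compound 4 is estimated at 120 nM in this assay, with a range from 50 nM to 300 nM.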

Compound 4, half-maximal inhibitory concentration: 170 nM
Compound 4: middle estimate off by 1.4-fold (0.15 log units), on the low side; the range from low to high includes it.
By their numbers in this assay, from the lowest: compounds 1, 2, 3 and 4 (each within the scatter of the next).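

In this assay, the exchange of 4-fluorophenyl for 4-methylphenyl on the sulfonyl group gives a 1.5-fold higher number from compound 1 to compound 4 (0.19 log units; within the scatter) and so stays within the scatter. Within the data shown here, this is the first measured step at this part of the molecule, and it shows that methyl and fluoro at this place cannot be told apart here. Nothing on hand bears on this result. From the compounds shown here alone, whether an amine, a carboxylic acid or a methoxy group at this place would move the number beyond the scatter remains open, as does the effect of removing the sulfonyl group altogether.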